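The compounds below may be only part of what the source reports. "The series", "measured", "known", "first", "only" and "open" are said of these compounds alone.

Three compounds with a shared core, such as that of compound 1 `COC(=O)c1cccc(C)c1OC(=O)COc1cc(O)c2c(=O)cc(-c3ccccc3)oc2c1`, were tested in a functional assay on cells (T-cell, Mus musculus, strain BALB/c) for inhibition, read by MTT assay, with a stated time of 72 h; a lower number here means a stronger inhibitor, a higher number a weaker inhibitor. Compound 1 gives 39100 nM, the second highest of the three numbers. Compound 2 `C=C(CCc1cc(O)c2c(=O)cc(-c3ccccc3)oc2c1)Cc1c(Br)cccc1C(=O)CC` gives 40700 nM, which is within the scatter of compound 1. Compound 3 `COC(=O)c1cc(Br)ccc1OC(=O)COc1cc(O)c2c(=O)cc(-c3ccccc3)oc2c1` gives 780 nM, and the step of a 50-fold lower number from compound 1 to compound 3 (1.70 log units; beyond the scatter) is large. Compound 4 `COC(=O)c1c(Cl)cccc1OC(=O)COc1cc(O)c2c(=O)cc(-c3ccccc3)oc2c1` differs from compound 1 by a group of 11 heavy atoms (8 carbon, 2 oxygen, 1 chlorine; one six-membered aromatic ring of carbon only) in place of a group of 11 heavy atoms (9 carbon, 2 oxygen; one six-membered aromatic ring of carbon only), on an oxygen next to a carbonyl group. Going by the values given here, the only step that bears on this is the one to compound 3, where a bromine-bearing ring in place of the methyl-bearing ring lowered the number sharply. A chlorine at another place is a weaker analogy, so a smaller step is expected in this assay, and compound 4 is estimated at 8000 nM (range 1500 nM to 40000 nM), a step of a 4.9-fold lower number from compound 1 to compound 4 (0.69 log units; beyond the scatter).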

Compound 4, half-maximal inhibitory concentration: 38900 nM
For compound 4 the middle estimate is 4.9-fold (0.69 log units) below the measured one; low and high end bracket the measured number.
By their numbers in this assay, from the lowest: compound 3; then compounds 4, 1 and 2 (each within the scatter of the next).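

Replacing the methyl-bearing ring with 3-chloro-2-(methoxycarbonyl)phenyl on this oxygen leaves the number unchanged (a 1.0-fold lower number from compound 1 to compound 4 (0.00 log units; within the scatter)), so a halogen on the ring does not by itself give a low number. Changing from 4-bromo-2-(methoxycarbonyl)phenyl to 3-chloro-2-(methoxycarbonyl)phenyl gives a large rise (a 50-fold higher number from compound 3 to compound 4 (1.70 log units; beyond the scatter)), so the low number of compound 3 belongs to that particular group. Nothing measured here explains this difference. The two groups differ in both the halogen and its place on the ring, and these compounds cannot separate the two. As far as these compounds go, how an amine or a carboxylic acid at the bromine's place would read also remains open.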